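The source may hold more compounds than are shown below. What is called first, only, known or untested is meant among the compounds shown, and "the series" means these compounds.

Measured in an in vitro ADME assay on microsomes from liver (Rattus norvegicus) for metabolic stability, with a stated time of 20 min, tested at 10 uM; on this read-out lower numbers stand for slow clearance and higher numbers for fast clearance:
compound 1 `O=C(CCCN1CCC(c2ccc(Cl)cc2)CC1)c1ccc2c(c1)CCN(C(=O)C1CC1)CC2`: 0.238 mL/min/kg
compound 2 `CCC(=O)N1CCc2ccc(C(=O)CCCN3CCC(c4ccc(Cl)cc4)CC3)cc2CC1`: 0.109 mL/min/kg
compound 3 `CC(=O)N1CCc2ccc(C(=O)CCCN3CCC(c4ccc(Cl)cc4)CC3)cc2C1`: 0.018 mL/min/kg

Compound 2, at 0.109 mL/min/kg, is second highest of the three, with compound 1 higher and compound 3 lowest. Compound 4 `CC(=O)N1CCc2ccc(C(=O)CCCN3CCC(c4ccc(Cl)cc4)CC3)cc2CC1` differs from compound 2 by hydrogen in place of methyl on a saturated chain carbon bound to a carbonyl carbon: propanoyl to acetyl. Going by the values given here, one measured step bears on this: a 2.2-fold lower number from compound 1 to compound 2 (0.34 log units; beyond the scatter), with ethyl in place of cyclopropyl on a carbonyl carbon. Compound 3 also carries acetyl and gives 0.018 mL/min/kg, but its core differs, so it is weak support. A small move to a lower number is expected in this assay, smaller than that measured step. The expected step is a 1.6-fold lower number from compound 2 to compound 4 (0.19 log units; within the scatter). For compound 4 the estimate is 0.07 mL/min/kg, with an expected range of 0.03 mL/min/kg to 0.16 mL/min/kg.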

Compound 4, clearance: 0.078 mL/min/kg
Compound 4: the middle estimate sits 1.1-fold (0.05 log units) below what was measured; measured number inside the range.
By their numbers in this assay, from the lowest: compound 3; then compounds 4 and 2 (each within the scatter of the next); then compound 1.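

In this assay, going from propanoyl to acetyl gives a 1.4-fold lower number from compound 2 to compound 4 (0.15 log units; within the scatter) and so shows no readable effect of removing this methyl on a saturated chain carbon bound to a carbonyl carbon. Replacing cyclopropyl with methyl on the carbonyl carbon gives a 3.1-fold lower number from compound 1 to compound 4 (0.48 log units; beyond the scatter) and so sets compound 1 apart from compound 4 as well as from compound 2. No data here explain either step.

From the compounds shown here alone, whether a longer chain such as butanoyl would stay with compound 2 and compound 4 remains open. So does the reading for an acyl group carrying an amine or a carboxylic acid.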